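The compounds below may be only part of what the source reports. "The series", "measured", "known", "first", "only" and "open" are said of these compounds alone.

Compound 1 `Cc1ccc(-c2nnc(-n3[se]c4ccccc4c3=O)s2)cc1`: 13400 nM
Compound 2 `O=c1c2ccccc2[se]n1-c1nnc(-c2cc([N+](=O)[O-])cc([N+](=O)[O-])c2)s1`: 17900 nM

In a functional assay on A549 cells (Homo sapiens) for antiproliferative activity, read by CCK-8 assay, with a stated time of 48 h (a higher number here means a weaker inhibitor, a lower number a stronger inhibitor), compound 1 stands at the low end of the two numbers shown, yet compound 2 gives 17900 nM, a gap that lies within the scatter of repeated measurements, so the two cannot be told apart. Compound 3 `O=c1c2ccccc2[se]n1-c1nnc(-c2ccc(Cl)cc2)s1` has not been measured. It differs from compound 1 by chloro in place of methyl on an aromatic carbon. Within the data shown here, no measured pair of this kind is available, so no step beyond the scatter is expected in this assay in either direction. For compound 3 the expected value is 12000 nM, with a range from 5000 nM to 30000 nM, which is expected to mean a 1.1-fold lower number from compound 1 to compound 3 (0.05 log units; within the scatter).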

Compound 3, half-maximal inhibitory concentration: 10400 nM
Compound 3: middle estimate off by 1.2-fold (0.06 log units), on the high side; measured number inside the range.
By their numbers in this assay, from the lowest: compounds 3, 1 and 2 (each within the scatter of the next).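

Among these compounds, replacing methyl with chloro on the aromatic carbon para to a large group gives a 1.3-fold lower number from compound 1 to compound 3 (0.11 log units; within the scatter) in this assay, the first direct comparison at this position. This single exchange therefore leaves the number within the scatter, so these two groups cannot be told apart here. No measurement is available that offers an explanation for this result.

On these data alone, whether an amine, a carboxylic acid or a longer chain at this same place would move the number beyond the scatter remains open. So does whether the same exchange would behave alike on other cells.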